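Ethoxy for 2-methylphenyl on the shared core

The source may report more compounds than this note shows. Statements on the series, on what has been measured and on what is new or still open speak of the compounds shown alone.

Measured so far in a functional assay on KB cells (Homo sapiens) for cytotoxicity; a higher number here means a weaker inhibitor, a lower number a stronger inhibitor:
- compound 1 `Cc1ccc(Cn2cc(C(N)=O)c3c(N)ncnc32)cc1` gives only a limit, > 100000 nM.
- compound 2 `Cc1cccc(Cn2cc(C(N)=O)c3c(N)ncnc32)c1` gives only a limit, > 100000 nM.
- compound 3 `Cc1ccccc1Cn1cc(C(N)=O)c2c(N)ncnc21` gives only a limit, > 100000 nM.

Compound 3 stands at a limit, and so do its two neighbours (the limit of > 100000 nM in this assay, at which 3 of the 3 values shown sit). The steps between the methylphenyl isomers are therefore unreadable: a step that the two limits leave unreadable from compound 1 to compound 2, a step that the two limits leave unreadable from compound 1 to compound 3 and a step that the two limits leave unreadable from compound 2 to compound 3.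

Compound 4 `CCOCn1cc(C(N)=O)c2c(N)ncnc21` changes the group on the saturated chain carbon bound to the aromatic nitrogen: ethoxy in place of 2-methylphenyl on a saturated chain carbon bound to an aromatic nitrogen.

Among the measured compounds shown here, no measured step bears on this change; every step so far is unreadable, so no direction can be read from the series. Compound 3 itself gives only a limit, so the step of a number no higher from compound 3 to compound 4 (the limit leaves the size open) is merely an expectation. For compound 4 the estimate is 100000 nM, ranging from 30000 nM to 300000 nM.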

Compound 4, half-maximal inhibitory concentration: > 100000 nM
Compound 4: no number, only a limit (the forecaster's own chance of this, stated with the estimate: 70%); the middle value sits exactly at the limit.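

In this assay compound 4 gives only a limit, > 100000 nM. Its steps from compound 1, compound 2 and compound 3 cannot be read: the limit of > 100000 nM in this assay, at which 4 of the 4 values shown sit.

The compounds shown leave open whether any group at this place on the shared core gives a measurable value.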